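Hydrogen in place of fluoro on an aromatic carbon

The source may report more compounds than this note shows. Statements on the series, on what has been measured and on what is new or still open speak of the compounds shown alone.

Going by the values given here, compound 1 (`CC1(c2cc(NC(=O)c3ccc(C#N)cn3)ccc2F)Cc2c(F)cncc2C(N)=N1`) is the only compound here with a number so far. In a physicochemical assay for acid dissociation, read by capillary electrophoresis, compound 1 gives 7.6 as its result, so it cannot yet be ranked against anything. Its close relative compound 2 (`CC1(c2cc(NC(=O)c3ccc(C#N)cn3)ccc2F)Cc2c(ccnc2F)C(N)=N1`) offers no comparison, as compound 2 has the entry "not determined" (no result reported) in place of a number.

The open question is compound 3 (`CC1(c2cc(NC(=O)c3ccc(C#N)cn3)ccc2F)Cc2ccncc2C(N)=N1`), which has not been measured. It differs from compound 1 in one place (hydrogen in place of fluoro on an aromatic carbon): hydrogen in place of fluoro on an aromatic carbon, two atoms from the ring nitrogen. Among the compounds with values here, no measured pair shows what this swap does, so the expectation rests on the structural change alone, counted up from compound 1 at 7.6 as the starting point. An upward move of moderate size is expected, larger than the usual scatter of repeated measurements. The estimated move is a number 0.60 log units higher from compound 1 to compound 3 (beyond the scatter) in this assay as a forecast and not a result. For compound 3 the expected value is 8.2 with a likely range from 7.8 to 8.7 on this scale.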

Compound 3, acid dissociation constant: 9.5
Compound 3: middle estimate off by 1.30 log units, on the low side, and the stated range ends below it.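

In this assay the swap of fluoro for hydrogen on this aromatic carbon, two atoms from the ring nitrogen, leads to a number 1.90 log units higher from compound 1 to compound 3 (beyond the scatter) and so counts as a large step on this scale. This one place on the shared core therefore weighs heavily on the read-out: exchanging a single fluorine atom for a hydrogen atom, with the rest of the molecule unchanged, is enough to make the proton given up clearly less readily. Nothing shown here bears on the reason for a step of this size.

Going by these compounds alone, compound 2 has no number, so no step to it can be read, and the effect of fluoro at its different place on the core remains unknown. Equally open is where a chlorine atom, a methyl group or an amine on this same carbon would fall on this scale, with fluoro and hydrogen as the only two groups shown there.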